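The source may hold more compounds than are shown below. What is called first, only, known or untested is meant among the compounds shown, and "the series" means these compounds.

Compound 3 `COc1ccc2nc(-c3ccc(-n4c(C)ccc4-c4ccc(F)cc4)cc3)sc2c1` gives 2480 nM in a functional assay on MCF7 cells (Homo sapiens) for cytotoxicity, read by sulforhodamine B assay, with a stated time of 48 h; on this read-out lower numbers stand for stronger inhibition of growth and higher numbers for weaker inhibition of growth. Among the three measured compounds it stands second highest: its nearest neighbour is compound 1 `Cc1ccc(-c2ccc([N+](=O)[O-])cc2)n1-c1ccc(-c2nc3ccccc3s2)cc1`, which gives 2540 nM in this assay, a gap within the scatter, while the furthest is compound 2 `Cc1ccc(-c2ccc([N+](=O)[O-])cc2)n1-c1ccc(-c2nc3ccc(F)cc3s2)cc1`, which gives 918 nM, a gap beyond the scatter.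

Compound 4 `COc1ccc2nc(-c3ccc(-n4c(C)ccc4-c4ccc([N+](=O)[O-])cc4)cc3)sc2c1` differs from compound 3 by one change: nitro in place of fluoro on an aromatic carbon, on an aromatic carbon of a six-membered aromatic ring of carbon only, para to a large group.

Going by the values given here, the only measured step, a 2.8-fold lower number from compound 1 to compound 2 (0.44 log units; beyond the scatter), concerns fluoro in place of hydrogen on the core and does not bear on this change. Compound 1 carries the nitro group and compound 3 the fluoro group, but the two also differ on the core, and their values lie within the scatter of each other. Among the compounds with values here, with no step bearing directly on the change, no shift beyond the scatter is expected from compound 3 to compound 4: a 1.0-fold higher number from compound 3 to compound 4 (0.00 log units; within the scatter). Compound 4 is therefore estimated at 2500 nM, with a range from 1200 nM to 5200 nM.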

Compound 4, concentration for 50% growth inhibition: 3170 nM
For compound 4 the middle estimate is 1.3-fold (0.10 log units) below the measured one, within the range that was stated.
By their numbers in this assay, from the lowest: compound 2; then compounds 3, 1 and 4 (each within the scatter of the next).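

In this assay the change from 4-fluorophenyl to 4-nitrophenyl gives a 1.3-fold higher number from compound 3 to compound 4 (0.11 log units; within the scatter) and so stays within the scatter, which shows that with the methoxy core held fixed, these two groups are not told apart on this aromatic carbon para to a large group. With the nitro group held fixed, methoxy in place of hydrogen on the core gives a 1.2-fold higher number from compound 1 to compound 4 (0.10 log units; within the scatter) and also stays within the scatter. Methoxy in place of fluoro on the core gives a 3.5-fold higher number from compound 2 to compound 4 (0.54 log units; beyond the scatter) and is the only one of these new steps beyond the scatter, so among these compounds the step that exceeds the scatter lies on the core and not at the para carbon.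

Going by these compounds, whether an amine or a carboxylic acid at the para carbon would also stay within the scatter remains open. The data shown offer no explanation for any of these steps.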